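This account rests on a few compounds, and the source may have more. Where it says the series, first, only, none or still open, it means among the compounds named here.

In an ADME assay on the whole organism (plasma) for pharmacokinetics, with Rattus norvegicus as the target, with a stated time of 24 h, at a dose of 10 mg/kg by the oral route (a lower number here means less compound in the circulation, a higher number more compound in the circulation at the dose given), compound 1 `Cc1ccc2c(c1)c(-c1ccc[nH]c1=O)c(C(=O)NS(C)(=O)=O)n2Cc1cc(F)ccc1F` gives 10400 ng.h/mL, compound 2 `Cc1ccc2c(c1)c(-c1ccc[nH]c1=O)c(C(=O)NS(=O)(=O)C1CC1)n2Cc1cc(F)ccc1F` gives 4530 ng.h/mL and compound 3 `CCc1ccc2c(c1)c(-c1ccc[nH]c1=O)c(C(=O)NS(C)(=O)=O)n2Cc1cc(F)ccc1F` gives 35000 ng.h/mL, the highest of the three numbers. The next structure, compound 4 `CCc1ccc2c(c1)c(-c1ccc[nH]c1=O)c(C(=O)NS(=O)(=O)C(C)C)n2Cc1cc(F)ccc1F`, has isopropyl in place of methyl on a sulfonyl sulfur. For the measured compounds named here, no isopropyl example has been measured. Going by the values given here, the closest precedent is a 2.3-fold lower number from compound 1 to compound 2 (0.36 log units; beyond the scatter), a modest change beyond the scatter, for cyclopropyl in place of methyl at that same sulfur. The other measured change, a 3.4-fold higher number from compound 1 to compound 3 (0.53 log units; beyond the scatter), lies at a different place and only sets the higher starting level. A modest fall of similar size is therefore expected, with the estimated step being a 2.3-fold lower number from compound 3 to compound 4 (0.37 log units; beyond the scatter). The expected value for compound 4 is 15000 ng.h/mL, with an estimated range of 6500 ng.h/mL to 32000 ng.h/mL.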

Compound 4, area under the concentration-time curve: 411 ng.h/mL
For compound 4 the middle estimate is 36-fold (1.56 log units) above the measured one, and the stated range ends above it.
By their numbers in this assay, from the lowest: compound 4; then compound 2; then compound 1; then compound 3.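

In this assay, for the compounds shown here, the substituent on the sulfonyl sulfur matters far more than the earlier compounds suggested: isopropyl in place of methyl gives an 85-fold lower number from compound 3 to compound 4 (1.93 log units; beyond the scatter), whereas cyclopropyl in place of methyl on the core of compound 1 gives a 2.3-fold lower number from compound 1 to compound 2 (0.36 log units; beyond the scatter). The high level of compound 3 is therefore not retained with this change. Nothing available bears on the reason for the fall. On these data alone, whether isopropyl has the same effect on the core of compound 1 remains open. So does whether a straight propyl chain or an amine on the sulfonyl sulfur would behave like isopropyl.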